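Cytotoxicity notes: compound 2 to compound 3

The source may hold more compounds than are shown below. What is called first, only, known or untested is meant among the compounds shown, and "the series" means these compounds.

Compound 1 `Nc1nc(N2CCCC2)c2ncn(/C=C3/CC3(CO)CO)c2n1` and compound 2 `CSc1nc(N)nc2c1ncn2/C=C1/CC1(CO)CO` have been tested in an ADME assay on BCBL1 cells (Homo sapiens) for cytotoxicity, with a stated time of 7 days; on this read-out lower numbers stand for higher toxicity in this test and higher numbers for lower toxicity in this test. For compound 1 the read-out is a limit, > 20000 nM. For compound 2 the read-out is likewise a limit, > 20000 nM. The step that the two limits leave unreadable from compound 1 to compound 2 cannot be read because both values sit at the limit (the limit of > 20000 nM in this assay, at which 2 of the 2 values shown sit). Compound 3 `CCCCNc1nc(N)nc2c1ncn2/C=C1/CC1(CO)CO` differs from compound 2 by butylamino in place of methylsulfanyl on an aromatic carbon. Among the measured compounds shown here, no measured step reaches a number, so no size or direction can be drawn for compound 3, and the two limits leave only the expectation that compound 3 again stays near the limit. Compound 3 is expected to give 20000 nM, within 10000 nM to 40000 nM. The expected step is a number no higher from compound 2 to compound 3 (the limit leaves the size open).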

Compound 3, half-maximal cytotoxic concentration: > 20000 nM
Compound 3 was reported as a limit (the forecaster's own chance of this, stated with the estimate: 70%); the middle value sits exactly at the limit.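

Among the compounds shown here, no step among compound 1, compound 2 and compound 3 can be read in this assay, because each result is a limit and not a number: the limit of > 20000 nM in this assay, at which 3 of the 3 values shown sit.
The compounds shown leave open whether any group on this aromatic carbon gives a measurable half-maximal cytotoxic concentration.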